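A few compounds are considered here, and "the series" means these few. Any claim that something is new, unique, unknown or untested is made for them only; others in the source may bear on it.

For the measured compounds named here, in a functional assay on HeLa cells (Homo sapiens) for cytotoxicity, read by MTT assay, with a stated time of 72 h (on this read-out lower numbers stand for stronger inhibition and higher numbers for weaker inhibition), compound 1 (`O=C(CCc1ccc(O)c(O)c1)OCCCc1ccccc1`) gives 171000 nM, the only true number available so far. Compound 2 (`COCOc1ccc(/C=C/C(=O)OC/C=C/c2ccccc2)cc1OCOC`) is reported only as a limit, > 1000000 nM, so it gives no exact value for comparison. Compound 3 (`O=C(CCc1ccc(O)cc1)OCCCc1ccccc1`) has not yet been measured. It comes from compound 1 through a single change: hydrogen in place of hydroxy on an aromatic carbon. In words, this is hydrogen in place of hydroxy on an aromatic carbon, ortho to a hydroxy group and meta to a large group. Going by the values given here, no measured pair shows what this change does, so any forecast is rough. A moderate step toward a higher number in this assay, meaning weaker inhibition, is the expectation. The expected step runs a 2.0-fold higher number from compound 1 to compound 3 (0.31 log units; beyond the scatter). For compound 3, the estimated value is 350000 nM, with an expected range from 120000 nM to 1000000 nM.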

Compound 3, half-maximal inhibitory concentration: 317000 nM
Compound 3: the middle estimate sits 1.1-fold (0.04 log units) above what was measured; the measured number falls inside the stated range.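

This pair isolates a single place on the six-membered aromatic ring: with hydrogen in place of hydroxy, this assay shows a 1.9-fold higher number from compound 1 to compound 3 (0.27 log units; within the scatter) and so cannot separate the two compounds. The hydroxy group at this place, ortho to a hydroxy group and meta to a large group, therefore makes no difference that this test can resolve, as long as the other hydroxy group remains. The data in hand offer no measured property that bears on this small step.

From the compounds shown here alone, it remains open whether a different group at this place, such as an amine or a methoxy group, would give a clearer step. Going by these compounds, it is also open what would happen if the remaining hydroxy group gave way to hydrogen, or if a longer chain joined the ester to the phenyl ring.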